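A few compounds are considered here, and "the series" means these few. Any claim that something is new, unique, unknown or untested is made for them only; others in the source may bear on it.

Measured compounds:
compound 1 `O=C(O)c1cc(-c2cccc(COc3ccc4c(c3)CN(C3CCC3)C4=O)c2)ccc1Cl` — 90 nM
compound 2 `Cc1c(OCc2cccc(-c3ccc(Cl)c(C(=O)O)c3)c2)cc2c(c1C)C(=O)C(C1CCCC1)C2` — 180 nM
compound 3 `O=C(O)c1cc(-c2cccc(COc3ccc4c(c3)CCN(C3CCCC3)C4=O)c2)ccc1Cl` — 300 nM

In an assay on HEK293 cells for positive allosteric modulation of metabotropic glutamate receptor 2 (Rattus norvegicus), read by thallium flux (a higher number here means that more compound is needed for the effect, a lower number that less compound is needed), compound 1 gives the lowest of the three numbers. Compound 2 sits within the usual scatter of it, so no order between these two can be read; compound 3 lies beyond the scatter, at the higher end.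

Compound 4 `CCCN1Cc2cc(OCc3cccc(-c4ccc(Cl)c(C(=O)O)c4)c3)ccc2C1=O` differs from compound 1 in one place: propyl in place of cyclobutyl on an amide-type nitrogen in a ring. Among the compounds with values here, no measured pair shows this exact change, so its size is not known from the data. The acyclic chain replacing the small ring is expected to move the number little, with a slight lean toward a higher value, as suggested by compound 3 with 300 nM carrying a different ring on the same kind of nitrogen. Compound 4 is thus estimated at 200 nM, within 60 nM to 650 nM, meaning a step of a 2.2-fold higher number from compound 1 to compound 4 (0.35 log units; beyond the scatter) in this assay.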

Compound 4, half-maximal effective concentration: > 10000 nM
Compound 4: no number, only a limit; the forecaster's own chance of this, stated with the estimate: 5%; middle value at least 50-fold (1.69 log units) from the limit.
By their numbers in this assay, from the lowest: compounds 1, 2 and 3 (each within the scatter of the next, the first and the last beyond it). At a limit, above all of these: compound 4.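

In this assay, propyl in place of cyclobutyl on the amide-type nitrogen gives a large step, an at least 110-fold higher number from compound 1 to compound 4 (2.04 log units; beyond the scatter). Within the data shown here, this is the only step measured at this position, and it shows that the position does not accept this exchange of a ring for an open chain without a large rise in the number. The reading for compound 4, > 10000 nM, is a limit of the assay and not a number: the limit of > 10000 nM in this assay, at which 1 of the 4 values shown sits.

The compounds shown leave open whether the ring itself matters or only this particular chain. Cyclopropyl, isopropyl or a longer chain such as butyl on this nitrogen could separate the two.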